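Moving a Trifluoromethyl Group on a Hydrazone Series

The source may hold more compounds than are shown below. What is called first, only, known or untested is meant among the compounds shown, and "the series" means these compounds.

Compound 1 `CN(C(=O)NC(=O)c1cccc(C(F)(F)F)c1)c1nc(C(F)(F)F)c(C(=O)N/N=C/c2cc(C(F)(F)F)cc(C(F)(F)F)c2)s1` and compound 2 `CN(C(=O)NC(=O)c1ccc(C(F)(F)F)cc1)c1nc(C(F)(F)F)c(C(=O)N/N=C/c2cc(C(F)(F)F)cc(C(F)(F)F)c2)s1` share one core and differ only by 4-(trifluoromethyl)phenyl in place of 3-(trifluoromethyl)phenyl on a carbonyl carbon. In a functional assay on BCG823 cells (Homo sapiens) for inhibition, read by MTT assay, with a stated time of 72 h (on this read-out lower numbers stand for stronger inhibition and higher numbers for weaker inhibition), compound 1 gives 5.23 ug/mL, and compound 2 gives 1.77 ug/mL; this change made a 3.0-fold lower number from compound 1 to compound 2 (0.47 log units; beyond the scatter). Compound 3 `CN(C(=O)NC(=O)c1ccccc1F)c1nc(C(F)(F)F)c(C(=O)N/N=C/c2cccc(C(F)(F)F)c2)s1` rests on another core; the difference between the two cores is not broken down here. In this assay compound 3 gives 16.3 ug/mL, the highest number of the three. Compound 4 `CN(C(=O)NC(=O)c1ccccc1F)c1nc(C(F)(F)F)c(C(=O)N/N=C/c2ccc(C(F)(F)F)cc2)s1` is related to compound 3 by 4-(trifluoromethyl)phenyl in place of 3-(trifluoromethyl)phenyl on a carbon with a double bond to nitrogen. This is the same kind of change as between compound 1 and compound 2, but the place differs: there it sat on a carbonyl carbon whose other neighbour is an amide-type nitrogen, here on a carbon with a double bond to nitrogen. The step is expected to be a 1.8-fold lower number from compound 3 to compound 4 (0.26 log units; within the scatter), smaller than before, because the earlier step of a 3.0-fold lower number from compound 1 to compound 2 (0.47 log units; beyond the scatter) was made at a different place and serves only as a loose guide. Compound 4 is estimated at 9 ug/mL, within 4 ug/mL to 20 ug/mL.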

Compound 4, half-maximal inhibitory concentration: 3.87 ug/mL
Compound 4: middle estimate off by 2.3-fold (0.37 log units), on the high side, and the stated range ends above it.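

In this assay, 4-(trifluoromethyl)phenyl in place of 3-(trifluoromethyl)phenyl on a carbon with a double bond to nitrogen gave a 4.2-fold lower number from compound 3 to compound 4 (0.62 log units; beyond the scatter). Set beside the earlier step, the change lowered the number on both cores, and the two step sizes cannot be told apart: the same change on two cores in this assay, a 3.0-fold lower number (0.47 log units; beyond the scatter) from compound 1 to compound 2 and a 4.2-fold lower number (0.62 log units; beyond the scatter) from compound 3 to compound 4, 1.4-fold (0.15 log units) apart, within the scatter of two such steps

Among the compounds shown here, this agreement rests on only two pairs in this assay, with the change at a different place in each, and it shows neither that the change would carry to further cores nor why the number falls. The compounds shown leave open whether the same step would appear with a methoxy group or a chlorine atom in place of the trifluoromethyl group. They also leave open whether it would hold in other cell lines.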